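Amino-to-nitro swap on the benzylamide of compound 1

This account rests on a few compounds, and the source may have more. Where it says the series, first, only, none or still open, it means among the compounds named here.

Measured so far:
Compound 1 `CN(C)C1=Nc2ccccc2C(CC(=O)NCc2ccc(N)cc2)N1c1ccccc1` gives > 100000 nM in a functional assay on A549 cells (Homo sapiens) for inhibition, read by sulforhodamine B assay, with a stated time of 72 h (a lower number here means a stronger inhibitor of growth, a higher number a weaker inhibitor of growth), which is a limit of the assay and not a number.
Compound 2 `CC(C)(C)OC(=O)NCCCCCNC1=Nc2ccccc2C(CC(=O)NCc2ccccc2)N1c1ccccc1` gives 7740 nM in this assay.

Compound 1 therefore stands at the edge of what this assay reports: the limit of > 100000 nM in this assay, at which 1 of the 2 values shown sits. Compound 3 `CN(C)C1=Nc2ccccc2C(CC(=O)NCc2ccc([N+](=O)[O-])cc2)N1c1ccccc1` differs by nitro in place of amino on an aromatic carbon. Among the compounds with values here, no measured pair shows this change, and compound 2 differs from compound 1 in several places, so its value sets no direction. The step from compound 1 to compound 3 is expected to be an at least 1.6-fold lower number from compound 1 to compound 3 (0.22 log units; that floor lies within the scatter), modest and uncertain in direction. Compound 3 is estimated at 60000 nM, within 10000 nM to 300000 nM.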

Compound 3, concentration for 50% growth inhibition: > 100000 nM
Compound 3: no number, only a limit; the forecaster's own chance of this, stated with the estimate: 50%; at least 1.6-fold (0.22 log units) between middle value and limit.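

No step can be read from compound 1 to compound 3, as each gives a limit of the assay and not a number: the limit of > 100000 nM in this assay, at which 2 of the 3 values shown sit.

The compounds shown leave open what nitro in place of amino on an aromatic carbon does in this assay.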